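Chalcone-stilbene hybrids: aryl ketone variation in A549 assay

The source may report more compounds than this note shows. Statements on the series, on what has been measured and on what is new or still open speak of the compounds shown alone.

Measured compounds:
compound 1 `COc1ccc(/C=C/c2cc(OC)cc(OC)c2/C=C/C(=O)c2ccc(Cl)c(Cl)c2)cc1`, 5.9 ug/mL
compound 2 `CCCC(C)Oc1ccc(C(=O)/C=C/c2c(/C=C/c3ccc(OC)cc3)cc(OC)cc2OC)cc1`, 9.4 ug/mL
compound 3 `COc1ccc(/C=C/c2cc(OC)cc(OC)c2/C=C/C(=O)c2cccc(Cl)c2)cc1`, 5.6 ug/mL

In a functional assay on A549 cells (Homo sapiens) for antiproliferative activity, read by MTT assay, with a stated time of 48 h (on this read-out higher numbers stand for weaker inhibition and lower numbers for stronger inhibition), compound 2 gives the highest of the three numbers, but its nearest neighbour lies within the scatter: a 1.6-fold higher number from compound 1 to compound 2 (0.20 log units; within the scatter). Compound 1 gives 5.9 ug/mL and compound 3 gives 5.6 ug/mL, both within the scatter of compound 2. No ordering among the three can be claimed.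

Compound 4 `COc1ccc(/C=C/c2cc(OC)cc(OC)c2/C=C/C(=O)c2ccc(Cl)cc2)cc1` is not yet measured. Relative to compound 2 the change is chloro in place of 1-methylbutoxy on an aromatic carbon.

Among the compounds with values here, two measured steps bear on this change. The step from compound 2 to compound 3, a 1.7-fold lower number from compound 2 to compound 3 (0.22 log units; within the scatter), removes the same 1-methylbutoxy group from the aryl ketone and puts in a chloro, though on a different carbon. The step from compound 1 to compound 2, a 1.6-fold higher number from compound 1 to compound 2 (0.20 log units; within the scatter), is the reverse kind of exchange, with two chloro groups. Both lie within the scatter. The step from compound 1 to compound 3, a 1.1-fold lower number from compound 1 to compound 3 (0.02 log units; within the scatter), shows that moving or removing a single chloro on this ring also stays within the scatter.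

Accordingly compound 4 is expected to show no step beyond the scatter, a 1.4-fold lower number from compound 2 to compound 4 (0.16 log units; within the scatter), perhaps a slightly lower number. The estimate for compound 4 is 6.5 ug/mL, with a range from 3.2 ug/mL to 13 ug/mL.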

Compound 4, half-maximal inhibitory concentration: 6.4 ug/mL
The estimate for compound 4 lay 1.0-fold (0.01 log units) above the measured number; the measured number falls inside the stated range.
By their numbers in this assay, from the lowest: compounds 3, 1, 4 and 2 (each within the scatter of the next).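

In this assay the direct exchange on the aromatic carbon para to a large group gives a 1.5-fold lower number from compound 2 to compound 4 (0.17 log units; within the scatter), so at this place chloro and 1-methylbutoxy are not told apart, despite the difference in size between the two groups. The placing and number of chloro groups on the aryl ketone are not told apart either: the shift from 3-chlorophenyl to 4-chlorophenyl gives a 1.1-fold higher number from compound 3 to compound 4 (0.06 log units; within the scatter), and the loss of one chloro from 3,4-dichlorophenyl, now with the 4-chloro retained, gives a 1.1-fold higher number from compound 1 to compound 4 (0.04 log units; within the scatter). No measurement at hand accounts for this lack of separation.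

Whether any group at this carbon can move the number beyond the scatter remains open, as the compounds shown carry only chloro or 1-methylbutoxy on this ring, and an amine or a carboxylic acid there would test a different kind of group. All four compounds also share the same core, so it remains open whether the same lack of separation among these aryl ketones would hold on a changed core.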